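Furan-bearing benzimidazoles: a weakly cytotoxic set

The source may report more compounds than this note shows. Statements on the series, on what has been measured and on what is new or still open speak of the compounds shown alone.

Measured so far:
compound 1, `N=C1N=C(n2c(-c3ccco3)nc3ccccc32)CN1`: 63500 nM
compound 2, `CCOC(=O)CSc1nnc(Cn2c(-c3ccco3)nc3ccccc32)s1`: 62100 nM
compound 3, `Cc1ccc(-c2nc3ccccc3n2CC(=O)N/N=C/c2ccccc2Cl)o1`: 22600 nM

Three compounds built on a shared core carrying a furan-2-yl group have been tested in a functional assay on HepG2 cells (Homo sapiens) for cytotoxicity, read by sulforhodamine B assay, with a stated time of 48 h; on this read-out lower numbers stand for stronger inhibition and higher numbers for weaker inhibition. Compound 1 gives 63500 nM, the highest of the three numbers. Compound 2 gives 62100 nM, which lies within the usual scatter of the number for compound 1. Compound 3 gives 22600 nM, a lower number that stands beyond the scatter.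

Compound 4, `S=c1[nH]nc(Cn2c(-c3ccco3)nc3ccccc32)s1`, has not yet been measured in this assay. It differs from compound 1 in one place: a group of 7 heavy atoms (3 carbon, 2 nitrogen, 2 sulfur; one five-membered aromatic ring with 3 hetero atoms) in place of a group of 6 heavy atoms (3 carbon, 3 nitrogen; one five-membered non-aromatic ring with 2 hetero atoms), on an aromatic nitrogen. Among the measured compounds shown here, no measured pair shows a step of this kind, so its size cannot be read from the data. Compound 2 carries a closely related group at the same place and its value, 62100 nM, sits within the scatter of compound 1, which gives little ground to expect a move beyond the scatter. The step from compound 1 to compound 4 is therefore expected to be a 1.3-fold lower number from compound 1 to compound 4 (0.10 log units; within the scatter), a change no larger than the scatter. Compound 4 is estimated at 50000 nM, within a range from 20000 nM to 130000 nM.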

Compound 4, half-maximal inhibitory concentration: 47600 nM
Compound 4: the middle estimate sits 1.1-fold (0.02 log units) above what was measured; the measured number falls inside the stated range.
By their numbers in this assay, from the lowest: compound 3; then compounds 4, 2 and 1 (each within the scatter of the next).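

In this assay, among the compounds shown here, the exchange on an aromatic nitrogen, next to the ring atom that bears a furan-2-yl group, gives the first step that can be read at this position: a 1.3-fold lower number from compound 1 to compound 4 (0.13 log units; within the scatter). A five-membered aromatic ring with 3 hetero atoms can thus stand in place of a five-membered non-aromatic ring with 2 hetero atoms with no change beyond the scatter, even though the two groups differ in ring type and in their counts of hydrogen-bond donors and acceptors. No measurement at hand offers an explanation for this outcome.

Going by these compounds, whether an amine, a carboxylic acid or a longer chain on this aromatic nitrogen would move the number beyond the scatter remains open. The compounds shown also hold no pair in which the furan-2-yl group alone changes.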